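Working notes: amide variation at the carbonyl, compound 3 to 4

The compounds below may be only part of what the source reports. "The series", "measured", "known", "first", "only" and "open" are said of these compounds alone.

Three compounds on the shared core carry numbers in an assay (Rattus norvegicus) for inhibition of Fatty-acid amide hydrolase 1 (Homo sapiens); on this read-out higher numbers stand for weaker inhibition and lower numbers for stronger inhibition. Compound 1 `Nc1cccc(-c2cnc(C(=O)CCCCCCc3ccccc3)o2)c1` gives 19 nM. Compound 2 `NS(=O)(=O)c1ccc(-c2cnc(C(=O)CCCCCCc3ccccc3)o2)s1` gives 3 nM, and compound 3 `CN(C)C(=O)c1cnc(C(=O)CCCCCCc2ccccc2)o1` gives 2 nM. The steps among them all change the group on the aromatic carbon: a 6.3-fold lower number from compound 1 to compound 2 (0.80 log units; beyond the scatter) and a 9.5-fold lower number from compound 1 to compound 3 (0.98 log units; beyond the scatter), while a 1.5-fold lower number from compound 2 to compound 3 (0.18 log units; within the scatter). Compound 3 therefore holds the lowest of the three numbers, set apart from compound 1 by a step beyond the scatter but from compound 2 only within the scatter.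

Compound 4 `O=C(CCCCCCc1ccccc1)c1ncc(C(=O)N2CCOCC2)o1` is not yet measured. It differs from compound 3 in one place: morpholin-4-yl in place of dimethylamino on a carbonyl carbon. For the measured compounds named here, none of the measured steps touches this position; each of them replaces the group on the aromatic carbon and leaves the amide untouched. The measured steps thus offer no direct guide. What can be said is that compound 2 and compound 3, which differ considerably at the aromatic carbon, sit within the scatter of each other in this assay. The expectation for compound 4 in this assay is accordingly no step beyond the scatter, a 1.5-fold higher number from compound 3 to compound 4 (0.18 log units; within the scatter). Compound 4 is estimated at 3 nM, with a range from 1 nM to 9 nM.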

Compound 4, inhibition constant: 24 nM
Beside the measured number, compound 4's estimate is 8.0-fold (0.90 log units) below it, and the stated range ends below it.
By their numbers in this assay, from the lowest: compounds 3 and 2 (each within the scatter of the next); then compounds 1 and 4 (each within the scatter of the next).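

In this assay, the group on this carbonyl carbon proves not to be a silent position: morpholin-4-yl in place of dimethylamino gives a 12-fold higher number from compound 3 to compound 4 (1.08 log units; beyond the scatter), a large step from a change confined to the amide. The carbonyl amide on the aromatic carbon therefore does not by itself secure the low numbers, since (morpholin-4-yl)carbonyl in place of 5-sulfamoylthiophen-2-yl gives an 8.0-fold higher number from compound 2 to compound 4 (0.90 log units; beyond the scatter), while (morpholin-4-yl)carbonyl in place of 3-aminophenyl gives a 1.3-fold higher number from compound 1 to compound 4 (0.10 log units; within the scatter), leaving that pair within the scatter. No supporting data are available to explain the response of this position to the change.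

The compounds shown do not separate the contribution of the ring from that of the ring oxygen, a question that a piperidin-1-yl amide, with the ring but no oxygen, and a diethylamino amide, with the carbons but no ring, would address. Also open, going by these compounds, is whether the same exchange of dimethylamino for morpholin-4-yl gives a step of similar size on a shorter or longer chain than the one on the shared core.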